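The source may report more compounds than this note shows. Statements on the series, on what has been measured and on what is new or still open speak of the compounds shown alone.

Compound 1, `OC[C@H]1OC(n2cnc3c(SCc4ccccc4)nccc32)[C@H](O)[C@@H]1O`, gives 30% in a functional assay (Homo sapiens) for inhibition of Nucleic Acid, tested at 100 uM; on this read-out lower numbers stand for less inhibition and higher numbers for more inhibition at the one concentration tested (going by the name of the read-out).
Compound 2, `[O-][n+]1ccc2c(c1)ncn2C1O[C@H](CO)[C@@H](O)[C@H]1O`, gives 5% in this assay.
Compound 3, `[N-]=[N+]=Nc1nccc2c1ncn2[C@H]1C[C@H](O)[C@@H](CO)O1`, gives 4% in this assay.

Among these three numbers compound 1 stands highest. Its nearest neighbour is compound 2, whose number is lower by a gap beyond the usual scatter, and compound 3 lies furthest below it, also beyond the scatter. Among the measured compounds shown here, none of the three pairs differs in only one place, so no single structural step between measured compounds can be read off; the values show only that compound 1 sits well apart from the other two.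

Compound 4, `CSc1nccc2c1ncn2C1O[C@H](CO)[C@@H](O)[C@H]1O`, is not yet measured. It is derived from compound 1 by one change: hydrogen in place of phenyl on a saturated chain carbon bound to a sulfur. The benzylsulfanyl group of compound 1 becomes a methylsulfanyl group in compound 4.

For the measured compounds named here, no measured pair tells how this change behaves, so the expectation rests on how far compound 1 stands above compound 2 and compound 3. The step of a number 18 percentage points lower from compound 1 to compound 4 (beyond the scatter) is expected to be a moderate drop, since compound 1 gives 30% and the remaining compounds stay low. For compound 4 the estimate is 12%, with a range from 0% to 28%.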

Compound 4, a percentage reported as inhibition, at one concentration (the size of the read-out at that concentration, not a potency): 24%
Beside the measured number, compound 4's estimate is 12 percentage points below it, and the stated range covers the measured number.
By their numbers in this assay, from the lowest: compounds 3 and 2 (each within the scatter of the next); then compounds 4 and 1 (each within the scatter of the next).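

Replacing the phenyl with hydrogen, which turns benzylsulfanyl into methylsulfanyl, gives a number 6 percentage points lower from compound 1 to compound 4 (within the scatter) in this assay. Among the compounds shown here, this is the first step that can be read between two measured compounds, and it shows that on a saturated chain carbon bound to a sulfur, the phenyl ring can go without any change that stands out from the scatter, so the benzyl and methyl versions cannot be told apart here. Nothing on hand explains this result.

The compounds shown leave open whether the sulfur is needed at all, since an amine or a methoxy group in place of the methylsulfanyl group would test that. A longer chain such as butyl on the sulfur, or a carboxylic acid at the end of that chain, also remains to be compared with the methyl and benzyl versions.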